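Trimethoxyphenyl Pyrazolyl Chalcones and Cytotoxicity at Low Concentration

This account rests on a few compounds, and the source may have more. Where it says the series, first, only, none or still open, it means among the compounds named here.

Measured compounds:
compound 1, `COc1cc(-c2cc(/C=C/C(=O)c3ccc(N)cc3)[nH]n2)cc(OC)c1OC`, 100%
compound 2, `COc1ccc(C(=O)/C=C/c2cc(-c3cc(OC)c(OC)c(OC)c3)n[nH]2)cc1OC`, 97%
compound 3, `COc1ccc(-c2cc(/C=C/C(=O)c3ccc(N)cc3)[nH]n2)cc1OC`, 98%

In a functional assay on OVCAR-8 cells (Homo sapiens) for cytotoxicity, read by sulforhodamine B assay, with a stated time of 48 h, tested at 0.01 uM (on this read-out higher numbers stand for a weaker effect at the one concentration tested and lower numbers for a stronger effect), compound 1 gives 100%, compound 2 gives 97% and compound 3 gives 98%. All three numbers lie within the scatter of one another, so none of them can be called weaker or stronger than the others at this concentration. The step of a number 2 percentage points higher from compound 3 to compound 1 (within the scatter) is made by methoxy in place of hydrogen on an aromatic carbon. The step of a number 3 percentage points lower from compound 1 to compound 2 (within the scatter) is likewise within the scatter. How the core of compound 2 differs from the core of compound 3 is not broken down here.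

Compound 4, `COc1cc(C(=O)/C=C/c2cc(-c3cc(OC)c(OC)c(OC)c3)n[nH]2)cc(OC)c1OC`, has not yet been measured. It is reached from compound 2 by methoxy in place of hydrogen on an aromatic carbon, which is the same change as that from compound 3 to compound 1. Since that earlier step was a number 2 percentage points higher from compound 3 to compound 1 (within the scatter), and since compound 2 gives 97%, compound 4 is expected to show a step of about a number 1 percentage points higher from compound 2 to compound 4 (within the scatter) in this assay. The estimate for compound 4 is therefore 98%.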

Compound 4, a percentage reported as activity, at one concentration (the size of the read-out at that concentration, not a potency): 100%
Beside the measured number, compound 4's estimate is 2 percentage points below it, and the stated range covers the measured number.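

In this assay the added methoxy gives a number 3 percentage points higher from compound 2 to compound 4 (within the scatter), and the same change on the other core can be set beside it: the same change on two cores in this assay, a number 2 percentage points higher (within the scatter) from compound 3 to compound 1 and a number 3 percentage points higher (within the scatter) from compound 2 to compound 4, 1 percentage points apart, within the scatter of two such steps. The two cores therefore give no sign that this change reads differently from one to the other at the single concentration tested. Going by these compounds alone, this does not show that the methoxy has any effect of its own: both steps lie within the scatter, so their agreement is that of two steps that cannot be told from no step, and it covers only these two pairs.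

The compounds shown carry only methoxy and amino groups on their outer aromatic rings, which leaves open how a hydroxyl, a fluorine or a carboxylic acid in the same place would read. They also leave open whether the methoxy step would keep its size in a compound whose number lies clearly apart from these.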